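The source may hold more compounds than are shown below. What is called first, only, known or untested is meant among the compounds shown, and "the series" means these compounds.

Measured so far in an ADME assay on PA-1 cells (Homo sapiens) for cytotoxicity, read by MTT assay, with a stated time of 72 h; on this read-out lower numbers stand for stronger inhibition and higher numbers for weaker inhibition:

Compound 1, `COc1ccc(C2=C(c3cc(OC)c(OC)c(OC)c3)C(=O)C(OC(C)=O)C2)cc1`, gives < 1 ug/mL; this is a limit of the assay, not a number.
Compound 2, `COc1ccc(C2=C(c3cc(OC)c(OC)c(OC)c3)C(=O)C(O)C2)cc1`, gives < 1 ug/mL; this too is a limit rather than a number.
Compound 3, `COc1cc(C2=C(c3cc(C)c(OC)c(C)c3)C(O)CC2=O)cc(OC)c1OC`, gives > 100 ug/mL; this is likewise a limit, at the weak end of the range.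

Compound 2 and compound 1 differ in one place, (acetyl in place of hydrogen on an oxygen on a saturated carbon). The step that the two limits leave unreadable from compound 2 to compound 1 cannot be sized, since both compounds sit at the strong limit recorded in the limit of < 1 ug/mL in this assay, at which 2 of the 3 values shown sit. Compound 3 differs from compound 2 in more than one place, and the difference between the two cores is not broken down here; compound 3 stands alone at the other end, the weak limit recorded in the limit of > 100 ug/mL in this assay, at which 1 of the 3 values shown sits.

Compound 4, `COc1cc(C2=C(c3cc(C)c(OC)c(C)c3)C(OC(C)=O)CC2=O)cc(OC)c1OC`, has not yet been measured. It differs from compound 3 by acetyl in place of hydrogen on an oxygen on a saturated carbon, the same change that turns compound 2 into compound 1, made at the same kind of place. Going by the values given here, that earlier step gives no readable size, so the only guide is that compound 3 itself sits at the weak limit given in the limit of > 100 ug/mL in this assay, at which 1 of the 3 values shown sits. The step of a number no higher from compound 3 to compound 4 (the limit leaves the size open) is therefore expected to be small, with compound 4 likely to remain near the weak limit. Compound 4 is estimated at 100 ug/mL, between 30 ug/mL and 300 ug/mL.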

Compound 4, half-maximal inhibitory concentration: > 100 ug/mL
Compound 4 gave a limit, no number (the forecaster's own chance of this, stated with the estimate: 60%); the middle value lies on the limit itself.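

Compound 4 gives > 100 ug/mL, a limit and not a number. Compound 3 stands at the same limit, so the change from hydroxy to acetoxy between compound 3 and compound 4 has no size that can be read. The compounds shown leave open how far, if at all, the acetyl group shifts the result in this assay on either core, with all four values being limits.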